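Series note: ketone to isopropyl on the tetrazole chain

The source may report more compounds than this note shows. Statements on the series, on what has been measured and on what is new or still open speak of the compounds shown alone.

Measured so far:
compound 1 `CC(=O)Cn1nnnc1Cc1ccc(-c2ccccc2)cc1` — > 100000 nM in this assay
compound 2 `CC(=O)Cn1nnc(Cc2ccc(-c3ccccc3)cc2)n1` — > 100000 nM in this assay

Activity was read in a functional assay on HEK293 cells for agonist activity at transient receptor potential cation channel subfamily V member 1 (Homo sapiens), read by calcium flux; a lower number here means that less compound is needed, a higher number that more compound is needed for the effect. Compound 1 `CC(=O)Cn1nnnc1Cc1ccc(-c2ccccc2)cc1` gives only a limit there, > 100000 nM. Compound 2 `CC(=O)Cn1nnc(Cc2ccc(-c3ccccc3)cc2)n1` likewise gives only a limit, > 100000 nM. Within the data shown here, compound 2 therefore stands at the limit of > 100000 nM in this assay, at which 2 of the 2 values shown sit, so no number is known for it, and no measured step exists.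

Compound 3 `CC(C)Cn1nnc(Cc2ccc(-c3ccccc3)cc2)n1` differs from compound 2 by isopropyl in place of acetyl on a saturated chain carbon bound to an aromatic nitrogen; cut one bond further out, the change reads 2-oxopropyl to isobutyl. With both measured compounds at the limit, no direction can be read from the data. Compound 3 is expected to remain at the same limit, the step from compound 2 being estimated as a number no higher from compound 2 to compound 3 (the limit leaves the size open). The estimate for compound 3 is 100000 nM, in the range 30000 nM to 300000 nM.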

Compound 3, half-maximal effective concentration: 10000 nM
Compound 3: the middle estimate sits 10-fold (1.00 log units) above what was measured, and the stated range ends above it.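

In this assay, isopropyl in place of acetyl on a saturated chain carbon bound to an aromatic nitrogen gives an at least 10-fold lower number from compound 2 to compound 3 (1.00 log units; beyond the scatter). This position therefore responds to the group it carries, which compound 1 and compound 2 could not show, as both gave only a limit. The step is a bound and not a full size, as the value for compound 2 is a limit: the limit of > 100000 nM in this assay, at which 2 of the 3 values shown sit.

The compounds shown do not tell whether an amine, a hydroxyl group or a longer chain at this place would lower the number further, or whether a carbonyl-free group is what matters. As far as these compounds go, it also remains open whether the same change on the core of compound 1 would produce a similar step.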